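The source may hold more compounds than are shown below. What is called first, only, known or untested is meant among the compounds shown, and "the series" means these compounds.

Measured in an ADME assay on the whole organism (Rattus norvegicus) for pharmacokinetics, at a dose of 0.5 mg/kg by the intravenous route; a higher number here means faster removal of the compound, a lower number slower removal:
- compound 1 `CNC(=O)Nc1cc(Oc2cncc(OC)c2)c([C@H]2COCC[C@@H]2F)cn1`: 26.7 mL/min/kg
- compound 2 `CNC(=O)Nc1cc(Oc2cncc(OC)c2)c([C@H]2CCCOC2)cn1`: 28.3 mL/min/kg
- compound 3 `CNC(=O)Nc1cc(Oc2cncc(OC)c2)c(C2=CCCOC2)cn1`: 38.3 mL/min/kg

These three compounds share a core and differ only in one ring group. At 38.3 mL/min/kg, compound 3 lies within the scatter of both other compounds, so this assay does not separate the three.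

Compound 4 `CNC(=O)Nc1cc(Oc2cncc(OC)c2)c(C2CCOCC2)cn1` is the next to be considered. Its difference from compound 3 is a group of 6 heavy atoms (5 carbon, 1 oxygen; one six-membered non-aromatic ring with 1 hetero atom) in place of a group of 6 heavy atoms (5 carbon, 1 oxygen; one six-membered non-aromatic ring with 1 hetero atom), on an aromatic carbon, on an aromatic carbon of a six-membered aromatic ring with 1 nitrogen, para to a (methylcarbamoyl)amino group. Within the data shown here, no measured compound carries oxan-4-yl, so the evidence is indirect. The closest measured change is a 1.4-fold higher number from compound 2 to compound 3 (0.13 log units; within the scatter), which also exchanges one six-membered ring group for another of the same heavy-atom count. The other two steps, a 1.1-fold higher number from compound 1 to compound 2 (0.03 log units; within the scatter) and a 1.4-fold higher number from compound 1 to compound 3 (0.16 log units; within the scatter), are also small. All three lie within the scatter, and none gives a firm direction.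

The expectation is therefore no change beyond the scatter, with the estimate placed among the three measured values, close to compound 2 at 28.3 mL/min/kg. The estimated step is a 1.3-fold lower number from compound 3 to compound 4 (0.11 log units; within the scatter). Compound 4 is expected to give 30 mL/min/kg, with an estimated range of 17 mL/min/kg to 52 mL/min/kg.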

Compound 4, clearance: 46.7 mL/min/kg
Estimate against measurement, compound 4: 1.6-fold (0.19 log units) below, within the range that was stated.
By their numbers in this assay, from the lowest: compounds 1, 2, 3 and 4 (each within the scatter of the next).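

In this assay the oxan-4-yl group of compound 4 adds a new point of ring attachment at this aromatic carbon, two atoms from the ring nitrogen and para to the (methylcarbamoyl)amino group, and the change still does not separate the compounds: the step with oxan-4-yl in place of oxan-3-yl is a 1.7-fold higher number from compound 2 to compound 4 (0.22 log units; within the scatter) and the step with oxan-4-yl in place of 4-fluorooxan-3-yl is a 1.7-fold higher number from compound 1 to compound 4 (0.24 log units; within the scatter) in that read-out. Losing the double bond outside aromatic rings gives a 1.2-fold higher number from compound 3 to compound 4 (0.09 log units; within the scatter) and so also stays inside the usual variation, which means that across these four compounds no tested change of the ring group at this position gives a step beyond the scatter. No supporting measurement bears on this result, so the data offer no account of it.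

The compounds shown leave open whether a basic ring such as piperidin-4-yl, a carboxylic acid or an open-chain ether at this carbon would give a step beyond the scatter. They also leave open how changes elsewhere would behave, as the (methylcarbamoyl)amino group and the rest of the shared core stay the same throughout.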